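Difluorobenzamide Analogue Expected to Stay Above Lipophilicity Limit

The source may hold more compounds than are shown below. What is called first, only, known or untested is meant among the compounds shown, and "the series" means these compounds.

Compound 1 `Cc1cc(C(=O)NC(C)C)nn1Cc1cc(Cl)ccc1OCc1ccccc1` gives > 3.7 in a physicochemical assay for lipophilicity, at pH 7.4 (on this read-out higher numbers stand for higher lipophilicity and lower numbers for lower lipophilicity), which is a limit of the assay rather than a number.
Compound 2 `Cc1cc(C(=O)Nc2ccccc2)nn1Cc1cc(Cl)ccc1OCc1ccccc1` gives > 3.7 in this assay, again a limit.
Compound 3 `Cc1cc(NC(=O)c2ccccc2)nn1Cc1cc(Cl)ccc1OCc1ccccc1` gives > 3.7 in this assay, also a limit.

Compound 2 therefore stands at the limit that all three measured compounds share (the limit of > 3.7 in this assay, at which 3 of the 3 values shown sit), so no number places it above or below compounds 1 and 3. Compound 4 `Cc1cc(NC(=O)c2c(F)cccc2F)nn1Cc1cc(Cl)ccc1OCc1ccccc1` differs from compound 2 by ((2,6-difluorophenyl)carbonyl)amino in place of phenylcarbamoyl on an aromatic carbon. The measured steps that touch this position, a step that the two limits leave unreadable from compound 1 to compound 2, a step that the two limits leave unreadable from compound 1 to compound 3 and a step that the two limits leave unreadable from compound 2 to compound 3, are all unreadable, since each runs from one limit to another, and none can show whether the change moves the read-out beyond the scatter. None of them involves fluorine. The closest comparison is the step from compound 2 to compound 3, which swaps phenylcarbamoyl for benzamido and still ends at the limit. Compound 4 is therefore expected to come back at or beyond that same limit, with a step that the limit leaves unreadable from compound 2 to compound 4 as the expected step and no readable change. The estimate for compound 4 is 4.3, ranging from 3.7 to 5, and it will most likely be reported only as the limit once more.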

Compound 4, distribution coefficient: > 3.7
Compound 4 ended at the assay's limit (the forecaster's own chance of this, stated with the estimate: 85%); the middle value does not contradict the limit.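

Compound 4 sits at the same limit as compound 1, compound 2 and compound 3, so no step among these compounds can be read, including those to compound 4: the limit of > 3.7 in this assay, at which 4 of the 4 values shown sit.

On these data alone, how far each compound lies past that limit stays open, and so does whether 2,6-difluorophenyl in place of phenyl on the carbonyl carbon changes the result in this assay at all.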